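Expected solubility of a pyrrolidinyl analogue of compound 2

The compounds below may be only part of what the source reports. "The series", "measured", "known", "first", "only" and "open" are said of these compounds alone.

Compound 1 `CCCn1cc(S(=O)(=O)c2ccc(CNC(=O)N3Cc4ccncc4C3)cc2)cn1` gives 105000 nM
Compound 2 `O=C(NCc1ccc(S(=O)(=O)N2CCC(O)CC2)cc1)N1Cc2ccncc2C1` gives 174000 nM

Among the compounds with values here, in a physicochemical assay for solubility, in phosphate buffer, with a stated time of 24 h, at pH 7.4, tested at 100 uM (on this read-out lower numbers stand for lower solubility and higher numbers for higher solubility), compound 2 reads 174000 nM and lies within the usual scatter of compound 1, the only other number available, so neither can be ranked above the other.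

Compound 3 (`O=C(NCc1ccc(S(=O)(=O)N2CCC(N3CCCC3)CC2)cc1)N1Cc2ccncc2C1`) differs from compound 2 in one place (pyrrolidin-1-yl in place of hydroxy on a saturated ring carbon): pyrrolidin-1-yl stands in place of hydroxy on a saturated ring carbon. Within the data shown here, no measured step replaces the hydroxy itself, so the data offer no direct guide to this change. Among the measured compounds shown here, one step bears on it loosely, as it exchanges the whole group on the sulfonyl sulfur, with 4-hydroxypiperidin-1-yl in place of 1-propyl-1H-pyrazol-4-yl (a 1.7-fold higher number from compound 1 to compound 2 (0.22 log units; within the scatter)). Even that larger exchange stayed within the scatter. With only this to go on, no step beyond the scatter is expected in this assay, and no direction is clearly favoured. The estimated step is small (a 1.2-fold lower number from compound 2 to compound 3 (0.06 log units; within the scatter)). Compound 3 is expected to read about 150000 nM, with an estimated range from 80000 nM to 260000 nM.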

Compound 3, solubility: 6200 nM
For compound 3 the middle estimate is 24-fold (1.38 log units) above the measured one; the measured number lies below the stated range.
By their numbers in this assay, from the lowest: compound 3; then compounds 1 and 2 (each within the scatter of the next).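

In this assay, the saturated ring carbon three ring bonds from the ring nitrogen proves to be a place where a single exchange can move the number far: pyrrolidin-1-yl in place of hydroxy gives a 28-fold lower number from compound 2 to compound 3 (1.45 log units; beyond the scatter). The earlier exchange on the sulfonyl sulfur stayed within the scatter, at a 1.7-fold higher number from compound 1 to compound 2 (0.22 log units; within the scatter), but 4-(pyrrolidin-1-yl)piperidin-1-yl in place of 1-propyl-1H-pyrazol-4-yl gives a 17-fold lower number from compound 1 to compound 3 (1.23 log units; beyond the scatter), so a change of the group on the sulfonyl sulfur is not always a quiet one, and compound 3 now stands well apart from the other two. Nothing available on these compounds accounts for this large step.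

The compounds shown leave open whether the lower number goes with the nitrogen of the pyrrolidin-1-yl group, with its carbons, or with its ring. A dimethylamino group, a methoxy group or a carboxylic acid on the same saturated ring carbon would help to tell these apart, since each keeps only part of what changes between hydroxy and pyrrolidin-1-yl.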